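Chain methyl removal: from compound 2 to compound 3

A few compounds are considered here, and "the series" means these few. Any claim that something is new, unique, unknown or untested is made for them only; others in the source may bear on it.

Of the compounds shown here, two carry numbers so far. Compound 1 `c1ccc(OCC2=NCCN2)c(CC2CC2)c1` gives 234 nM in an assay on isolated protein for agonist activity at Alpha-2C adrenergic receptor (Homo sapiens); a lower number here means that less compound is needed, a higher number that more compound is needed for the effect. Compound 2 `CCCc1ccccc1OC(C)C1=NCCN1` gives 25.1 nM in this assay, the lowest of the two numbers; its nearest neighbour, compound 1, sits at a higher number, and that gap lies beyond the scatter. For the measured compounds named here, compound 1 and compound 2 differ in more than one place, so no single step between them can be read off.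

Compound 3 `CCCc1ccccc1OCC1=NCCN1` has not yet been measured. It differs from compound 2 by hydrogen in place of methyl on a saturated chain carbon bound to a carbon with a double bond to nitrogen and an oxygen on an aromatic ring. Going by the values given here, no measured pair shows this change on its own, so the size and direction of the step are not known from the data. The expectation is a small move toward a higher number, of about the size a 2.4-fold higher number from compound 2 to compound 3 (0.38 log units; beyond the scatter), which may still fall within the scatter. For compound 3 in this assay the estimate is 60 nM, with a range from 15 nM to 250 nM.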

Compound 3, half-maximal effective concentration: 155 nM
Compound 3: middle estimate off by 2.6-fold (0.41 log units), on the low side; the range from low to high includes it.
By their numbers in this assay, from the lowest: compound 2; then compounds 3 and 1 (each within the scatter of the next).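

In this assay, the methyl on a saturated chain carbon bound to a carbon with a double bond to nitrogen and an oxygen on an aromatic ring now has a measured single-place step: hydrogen in its place gives a 6.2-fold higher number from compound 2 to compound 3 (0.79 log units; beyond the scatter). For the compounds shown here, this is the first change that can be read on its own, and it shows that this one methyl carries a step beyond the scatter. The second readable change, ethyl in place of cyclopropyl on a saturated chain carbon bound to an aromatic carbon, gives a 1.5-fold lower number from compound 1 to compound 3 (0.18 log units; within the scatter), which is within the scatter, so this assay does not separate these two groups at that place. No other data bear on what lies behind either step.

The compounds shown leave open whether the methyl step would carry over to the cyclopropyl-bearing compound 1, since only one pair shows this change. They also leave open what a longer chain, such as propyl, or a fluorine at the same saturated chain carbon would do to the number in this assay.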